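The source may report more compounds than this note shows. Statements on the series, on what has been measured and on what is new or still open speak of the compounds shown alone.

Measured compounds:
Compound 1 `Cc1nnc(CN2CCCC2)n1-c1ccc(Cl)cc1C(=O)c1ccccc1Cl`: in a functional assay on the whole organism (strain CF-1) for positive allosteric modulation, with Mus musculus as the target (a higher number here means that more compound is needed for the effect, a lower number that less compound is needed), compound 1 gives 6 mg/kg.
Compound 2 `CN(C)Cc1nnc(C2CC2)n1-c1ccc(Cl)cc1C(=O)c1ccccc1Cl`: in this assay compound 2 gives 2.2 mg/kg.

Compound 2 holds the lower of the two numbers, and its gap to compound 1 lies beyond the usual scatter. Compound 3 `Cc1nnc(CN(C)C)n1-c1ccc(Cl)cc1C(=O)c1ccccc1Cl` is not yet measured. It differs from compound 2 in one place: methyl in place of cyclopropyl on an aromatic carbon. Among the measured compounds shown here, no measured pair shows this exact change, so the size of the step is open; a modest rise in the dose, or nothing beyond the scatter, is expected. Compound 3 is estimated at 3.2 mg/kg, within 1.6 mg/kg to 6.5 mg/kg, the expected step being a 1.5-fold higher number from compound 2 to compound 3 (0.16 log units; within the scatter).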

Compound 3, dose for half-maximal effect: 0.63 mg/kg
Beside the measured number, compound 3's estimate is 5.1-fold (0.71 log units) above it; measured number outside the range, below it.
By their numbers in this assay, from the lowest: compound 3; then compound 2; then compound 1.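

On the aromatic carbon between two ring nitrogen atoms, methyl in place of cyclopropyl gives a 3.5-fold lower number from compound 2 to compound 3 (0.54 log units; beyond the scatter) in this assay, so the group at this position moves the dose and the three-membered ring is not required for a low one. With methyl on that carbon in both compounds, dimethylamino in place of pyrrolidin-1-yl on the saturated chain carbon gives a 9.5-fold lower number from compound 1 to compound 3 (0.98 log units; beyond the scatter), so the amine end moves the dose as well. Nothing available explains either step.

Each change rests on a single pair. As far as these compounds go, how ethyl or hydrogen on the aromatic carbon, or diethylamino or morpholin-4-yl on the chain carbon, would compare with these groups stays open.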